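The source may report more compounds than this note shows. Statements on the series, on what has been measured and on what is new or still open speak of the compounds shown alone.

Measured compounds:
Compound 1, `O=C(/C=C/c1ccc(NC(=O)Nc2ccc(Cl)c(C(F)(F)F)c2)cc1)NC1CCC1`, gives 4530 nM in a functional assay on MX1 cells (Homo sapiens) for inhibition, read by MTT assay, with a stated time of 120 h; a higher number here means a weaker inhibitor, a lower number a stronger inhibitor.
Compound 2, `C/C(=C\C(=O)N1CC(C)OC(C)C1)c1ccc(NC(=O)Nc2ccc(Cl)c(C(F)(F)F)c2)cc1`, gives > 50000 nM in this assay, which is a limit of the assay and not a number.
Compound 3, `CNC(=O)/C=C(\C)c1ccc(NC(=O)Nc2ccc(Cl)c(C(F)(F)F)c2)cc1`, gives > 50000 nM in this assay, again a limit and not a number.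

Compound 3 therefore stands at the limit of this assay, and only compound 1 of the three measured compounds carries an actual number; two of the three values sit at the limit of > 50000 nM in this assay, at which 2 of the 3 values shown sit. Among the compounds with values here, the one readable step into compound 3 is an at least 11-fold higher number from compound 1 to compound 3 (1.04 log units; beyond the scatter), a large loss, while a step that the two limits leave unreadable from compound 2 to compound 3 cannot be read because both ends are limits.

Compound 4, `C/C(=C\C(=O)NC(C)c1ccccc1)c1ccc(NC(=O)Nc2ccc(Cl)c(C(F)(F)F)c2)cc1`, differs from compound 3 by 1-phenylethyl in place of methyl on an amide-type nitrogen. Compound 2 shows that a larger group on the amide, with the methyl kept on the double bond, still sits at the limit, so no gain beyond the scatter is expected for an at least 1.2-fold lower number from compound 3 to compound 4 (0.09 log units; that floor lies within the scatter). Compound 4 is expected to give about 40000 nM, within 10000 nM to 150000 nM, and most likely to be reported only as a limit.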

Compound 4, half-maximal inhibitory concentration: > 50000 nM
Compound 4 gave a limit, no number (the forecaster's own chance of this, stated with the estimate: 55%); middle value at least 1.2-fold (0.09 log units) away from the limit.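

Compound 4 stands at a limit of the assay, as do compound 2 and compound 3, so neither step from compound 2 or compound 3 to compound 4 can be read: the limit of > 50000 nM in this assay, at which 3 of the 4 values shown sit.

The compounds shown leave open how the amide group alone affects the number in this assay while the methyl stays on the double bond.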